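The compounds below may be only part of what the source reports. "The series", "measured", "known", "first", "only" and "open" are said of these compounds alone.

Compound 1, `O=S(=O)(Nc1ccc(F)c(C#Cc2cnc3[nH]ncc3c2)c1F)c1cccnc1`, gives 445 nM in a functional assay on COLO 205 cells (Homo sapiens) for antiproliferative activity, read by MTT assay, with a stated time of 68 h; a higher number here means a weaker inhibitor, a lower number a stronger inhibitor. Compound 2, `O=S(=O)(Nc1ccc(F)c(C#Cc2cnc3[nH]nc(C4CC4)c3c2)c1F)c1cccnc1`, is the related compound in which a cyclopropyl sits in place of a hydrogen on an aromatic carbon, and in this assay compound 2 gives 61 nM. Within the data shown here, that change is the only step measured so far, a 7.3-fold lower number from compound 1 to compound 2 (0.86 log units; beyond the scatter), and it places compound 2 as the lower of the two numbers, with compound 1 as its nearest neighbour.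

Compound 3, `O=S(=O)(Nc1ccc(F)c(C#Cc2cnc3[nH]nc(-c4cccc(Cl)c4)c3c2)c1F)c1cccnc1`, continues from compound 2 with a single change: 3-chlorophenyl in place of cyclopropyl on an aromatic carbon. Among the measured compounds shown here, no measured pair shows an aryl group at this position, so the one step available, from hydrogen to cyclopropyl, is the only guide. It shows that adding a group at this carbon lowered the number well beyond the scatter, which suggests the position tolerates substitution, but it says nothing about how a larger aromatic group will compare with cyclopropyl. Compound 3 is therefore expected to lie near compound 2, with a 1.5-fold lower number from compound 2 to compound 3 (0.18 log units; within the scatter) as the estimated step. The estimate for compound 3 in this assay is 40 nM, in a range from 10 nM to 200 nM.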

Compound 3, half-maximal inhibitory concentration: > 10000 nM
Compound 3: a limit, no number; the forecaster's own chance of this, stated with the estimate: 2%; at least 250-fold (2.39 log units) between middle value and limit.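

In this assay compound 3 gives only a limit and not a number: the limit of > 10000 nM in this assay, at which 1 of the 3 values shown sits. The earlier compounds shown here showed a single direction at this aromatic carbon, with cyclopropyl giving a lower number than hydrogen, but the 3-chlorophenyl group reverses that, giving an at least 160-fold higher number from compound 2 to compound 3 (2.21 log units; beyond the scatter). Set against hydrogen itself, the same group gives an at least 22-fold higher number from compound 1 to compound 3 (1.35 log units; beyond the scatter), so a group at this carbon can raise the number as well as lower it, and the direction depends on which group enters, not merely on whether the position is filled.

What remains open is which part of the 3-chlorophenyl group goes with the loss, the six-membered aromatic ring or the chlorine, since only one aryl group stands at this carbon in the compounds shown. An unsubstituted phenyl would separate those two parts, and an ethyl, an isopropyl or an amine at the same carbon would show whether anything other than cyclopropyl keeps the number below that of compound 1.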